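Halogen swap on the benzylsulfanyl group: bromo to fluoro

A few compounds are considered here, and "the series" means these few. Any claim that something is new, unique, unknown or untested is made for them only; others in the source may bear on it.

For the measured compounds named here, in an assay on isolated protein for binding affinity to Equilibrative nucleoside transporter 1 (Homo sapiens) (on this read-out higher numbers stand for weaker inhibition and lower numbers for stronger inhibition), compound 1 `OC[C@H]1O[C@@H](n2cnc3c(SC4CCCCC4)ncnc32)[C@H](O)[C@@H]1O` gives 6310 nM and compound 2 `OC[C@H]1O[C@@H](n2cnc3c(SCCCc4ccccc4)ncnc32)[C@H](O)[C@@H]1O` gives 1350 nM; the only measured step, a 4.7-fold lower number from compound 1 to compound 2 (0.67 log units; beyond the scatter), concerns the group carried on sulfur. Compound 3 `Nc1nc(SCc2ccc(Br)cc2)c2ncn([C@@H]3O[C@H](CO)[C@@H](O)[C@H]3O)c2n1` gives 813 nM, the smallest of the three numbers, with a gap to compound 2 that lies within the scatter and a gap to compound 1 that lies beyond it. Compound 4 `Nc1nc(SCc2ccc(F)cc2)c2ncn([C@@H]3O[C@H](CO)[C@@H](O)[C@H]3O)c2n1` differs from compound 3 by fluoro in place of bromo on an aromatic carbon. Going by the values given here, no measured step touches the substituent on the six-membered aromatic ring, so the step from cyclohexyl to 3-phenylpropyl offers no guide here. For compound 4 the expected step of a 1.5-fold higher number from compound 3 to compound 4 (0.17 log units; within the scatter) is therefore none beyond the scatter. Compound 4 is estimated at 1200 nM, range 400 nM to 4000 nM.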

Compound 4, half-maximal inhibitory concentration: 1150 nM
Compound 4: middle estimate off by 1.0-fold (0.02 log units), on the high side; low and high end bracket the measured number.
By their numbers in this assay, from the lowest: compounds 3, 4 and 2 (each within the scatter of the next); then compound 1.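

Bromo and fluoro on this aromatic carbon cannot be told apart in this assay, with a 1.4-fold higher number from compound 3 to compound 4 (0.15 log units; within the scatter) as the only measured change on the ring of the benzylsulfanyl group. For this pair, then, the choice between these two halogens does not separate the values. No measurement at hand bears on why the two stay so close.

On these data alone, a methoxy, a nitrile or a plain hydrogen at this carbon remains open. No pair shown isolates the amino group on the core of compound 3 and compound 4, or 4-bromobenzyl against 3-phenylpropyl on sulfur.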